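The source may hold more compounds than are shown below. What is called first, only, known or untested is meant among the compounds shown, and "the series" means these compounds.

Measured compounds:
compound 1, `N#Cc1ccc(NC(=S)N/N=C/c2ccc3ccccc3n2)cc1`: 15600 nM
compound 2, `S=C(NCc1ccccc1)N/N=C/c1ccc2ccccc2n1`: 75700 nM
compound 3, `NC(=S)N/N=C/c1ccc2ccccc2n1`: 100000 nM

Three analogues sharing one core have been tested in a functional assay on HT-29 cells (Homo sapiens) for antiproliferative activity, read by sulforhodamine B assay, with a stated time of 72 h; a lower number here means a stronger inhibitor, a higher number a weaker inhibitor. Compound 3 stands at the top of these three numbers: in this assay compound 3 gives 100000 nM, while compound 1 gives 15600 nM and compound 2 gives 75700 nM. The step of a 1.3-fold higher number from compound 2 to compound 3 (0.12 log units; within the scatter) is within the scatter, whereas a 6.4-fold higher number from compound 1 to compound 3 (0.81 log units; beyond the scatter) is beyond it, as is a 4.9-fold higher number from compound 1 to compound 2 (0.69 log units; beyond the scatter).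

Compound 4, `S=C(N/N=C/c1ccc2ccccc2n1)Nc1ccc(Cl)cc1`, is the next compound to be measured in this assay. Relative to compound 3 the change is 4-chlorophenyl in place of hydrogen on an amide-type nitrogen. Going by the values given here, the step that bears most on this is the one from compound 1 to compound 3, where replacing an aryl group on that nitrogen by hydrogen raised the number by a 6.4-fold higher number from compound 1 to compound 3 (0.81 log units; beyond the scatter); the reverse move, putting an aryl group back in place of hydrogen, is what compound 4 represents. The benzyl case, a 1.3-fold higher number from compound 2 to compound 3 (0.12 log units; within the scatter), shows that not every substituent on that nitrogen lowers the number. Since a 4-chlorophenyl group is an aryl group like the 4-cyanophenyl of compound 1, a step downward in this assay of roughly the size seen from compound 1 to compound 3 is expected, giving a 5.0-fold lower number from compound 3 to compound 4 (0.70 log units; beyond the scatter). Compound 4 is therefore estimated at 20000 nM, with a range from 8000 nM to 60000 nM.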

Compound 4, half-maximal inhibitory concentration: 97200 nM
For compound 4 the middle estimate is 4.9-fold (0.69 log units) below the measured one; the measured number lies above the stated range.
By their numbers in this assay, from the lowest: compound 1; then compounds 2, 4 and 3 (each within the scatter of the next).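

In this assay, 4-chlorophenyl in place of hydrogen on the amide-type nitrogen gives no separation (a 1.0-fold lower number from compound 3 to compound 4 (0.01 log units; within the scatter)), so an aryl group there is not enough by itself to lower the number. Set against benzyl, it also stays within the scatter (a 1.3-fold higher number from compound 2 to compound 4 (0.11 log units; within the scatter)), whereas chloro in place of cyano on an aromatic carbon is a step beyond it (a 6.2-fold higher number from compound 1 to compound 4 (0.79 log units; beyond the scatter)), which places the difference among these aryl compounds in that one substituent rather than in the ring as such. Nothing measured here offers an explanation for this difference.

On these data alone, it remains open whether the lower number of compound 1 is particular to the nitrile or would also appear with another group at that aromatic carbon, such as methoxy, an amine or a carboxylic acid. The plain phenyl, with hydrogen in place of the chloro or the cyano, also stands outside the compounds shown.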